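Reversing the One Stereocentre of Compound 2

The source may report more compounds than this note shows. Statements on the series, on what has been measured and on what is new or still open speak of the compounds shown alone.

In a physicochemical assay for solubility, at pH 1.1 (a higher number here means a more soluble compound, a lower number a less soluble compound), compound 1 `CCCN(Cc1ccc(OCCN2C(=O)CCC2=O)c(C)c1)C(CC(=O)O)c1ccc(Cl)cc1` gives 3000000 nM, and compound 2 `CCCN(Cc1ccc(OCCN2C(=O)CCC2=O)c(C)c1)[C@@H](CC(=O)O)c1ccc(Cl)cc1` gives 3000000 nM, so compound 2 stands level with compound 1 at the digits shown. The two differ only in the fact that one of compounds 1 and 2 is drawn with a defined configuration and the other without, at the place where they differ. Compound 3 `CCCN(Cc1ccc(OCCN2C(=O)CCC2=O)c(C)c1)[C@H](CC(=O)O)c1ccc(Cl)cc1` follows from compound 2 through a single change: the two compounds have the same atoms and bonds and differ only in configuration as drawn: 1 of 1 stereo elements differ; a stereocentre at a saturated chain carbon is drawn S in compound 2 and R in compound 3. Nothing leaves and nothing enters. Going by the values given here, only one measured step touches this stereocentre, namely no change at the digits printed from compound 1 to compound 2 (within the scatter), which lies within the scatter. Among the compounds with values here, no compound drawn R has yet been measured, so the evidence is thin. Within the data shown here, with only that step from compound 1 to go on, no shift in either direction is expected in this assay beyond the scatter. The expected step is no change at the digits printed from compound 2 to compound 3 (within the scatter). For compound 3 the estimated value is 3000000 nM, with an expected range of 1500000 nM to 4500000 nM.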

Compound 3, solubility: 3000000 nM
Compound 3: the middle estimate sits on the measured number at the digits printed, and the stated range covers the measured number.
By their numbers in this assay, from the lowest: compounds 1, 2 and 3 (each within the scatter of the next).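

Going by these compounds alone, with compound 3 the R configuration at this stereocentre at a saturated chain carbon now has a reading of its own in this assay, where the earlier compounds offered only the S form and the form drawn without a configuration. Reversing the centre gives no change at the digits printed from compound 2 to compound 3 (within the scatter), and the comparison with the undefined form gives no change at the digits printed from compound 1 to compound 3 (within the scatter), so in this assay neither defined configuration stands apart from the other or from the undefined form. This is a clean test of the centre alone, as the structures show: the fact that compounds 2 and 3 differ only in the configuration as drawn

The compounds shown leave open whether this centre would stay as silent in this assay if it carried a methyl group in place of its hydrogen. They also leave open whether a tetrazole in place of the carboxylic acid would keep the two configurations level.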